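Swapping the amide cap of a sub-nanomolar Substance-P antagonist

A few compounds are considered here, and "the series" means these few. Any claim that something is new, unique, unknown or untested is made for them only; others in the source may bear on it.

Compound 1 `CCC(=O)N1C[C@@H](O[C@H](C)c2cc(C(F)(F)F)cc(C(F)(F)F)c2)[C@H](c2ccc(F)cc2)C1` and compound 2 `C[C@@H](O[C@@H]1CN(C(=O)[C@@H]2CCC(=O)N2C)C[C@H]1c1ccc(F)cc1)c1cc(C(F)(F)F)cc(C(F)(F)F)c1` share a core and differ only in the group attached to the carbonyl carbon. In an assay on CHO cells for displacement of a labelled ligand from Substance-P receptor (Homo sapiens) (a higher number here means a weaker inhibitor, a lower number a stronger inhibitor), compound 1 gives 0.09 nM, and compound 2 gives 0.12 nM. The step of a 1.3-fold higher number from compound 1 to compound 2 (0.12 log units; within the scatter) shows that exchanging these two caps left the result essentially unchanged. Among the two measured values, compound 2 has the higher number, but its only neighbour, compound 1, sits within the scatter of it, so no real difference between them can be claimed.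

Compound 3 `Cc1cnc(C(=O)N2C[C@@H](O[C@H](C)c3cc(C(F)(F)F)cc(C(F)(F)F)c3)[C@H](c3ccc(F)cc3)C2)cn1` carries a further variation at the same position: 5-methylpyrazin-2-yl in place of 1-methyl-5-oxopyrrolidin-2-yl on a carbonyl carbon. Within the data shown here, the one measured step that bears on this, a 1.3-fold higher number from compound 1 to compound 2 (0.12 log units; within the scatter), changed the same position and stayed within the scatter, so a similarly small change is expected here, with no clear direction. The number for compound 3 in this assay is therefore estimated at 0.15 nM, with a likely range from 0.05 nM to 0.5 nM, corresponding to an expected step of a 1.3-fold higher number from compound 2 to compound 3 (0.10 log units; within the scatter).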

Compound 3, half-maximal inhibitory concentration: 0.12 nM
Compound 3: middle estimate off by 1.3-fold (0.10 log units), on the high side; the measured number falls inside the stated range.
By their numbers in this assay, from the lowest: compounds 1, 2 and 3 (each within the scatter of the next).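

The carbonyl carbon now carries three very different caps in this assay: a small ethyl, the non-aromatic 1-methyl-5-oxopyrrolidin-2-yl and the aromatic 5-methylpyrazin-2-yl, and both steps that bring in the last of these stay within the scatter (no change at the digits printed from compound 2 to compound 3 (within the scatter); a 1.3-fold higher number from compound 1 to compound 3 (0.12 log units; within the scatter)). Compound 2 and compound 3 have the same count of heavy atoms but differ in ring size, aromaticity and the defined stereocentre, which only the 1-methyl-5-oxopyrrolidin-2-yl cap holds, and none of these differences appears in the read-out for this pair. The earlier step could show only that a five-membered lactam cap matched ethyl, whereas these results extend that match to a six-membered aromatic ring with two nitrogens, though nothing here accounts for it.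

As far as these compounds go, whether the same flat response would hold for an amine, a carboxylic acid or a much longer alkyl chain on this carbonyl carbon stays open. Also open, from the compounds shown here alone, is whether the 1-methyl-5-oxopyrrolidin-2-yl cap with its stereocentre inverted would give a comparable number.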